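Compound 3 Against Compound 2: Cytotoxicity Notes

A few compounds are considered here, and "the series" means these few. Any claim that something is new, unique, unknown or untested is made for them only; others in the source may bear on it.

Measured so far in an ADME assay on HuhET cells (Homo sapiens) for cytotoxicity, read by thymidine incorporation; on this read-out lower numbers stand for higher toxicity in this test and higher numbers for lower toxicity in this test:
- compound 1 `COC(=O)N[C@H](C(=O)N1C[C@@H](C)C[C@H]1c1nc2cc(-c3ccc(-c4cc5[nH]c([C@@H]6C[C@H](C)CN6C(=O)[C@@H](NC(=O)OC)C(C)C)nc5s4)cc3)ccc2[nH]1)C(C)C` gives > 20000 nM as a limit of the assay
- compound 2 `COC(=O)N[C@H](C(=O)N1C[C@@H](C)C[C@H]1c1ncc(-c2ccc(-c3ccc(-c4cc5[nH]c([C@@H]6C[C@H](C)CN6C(=O)[C@@H](NC(=O)OC)C(C)C)nc5s4)cc3F)cc2)[nH]1)C(C)C` gives 20000 nM as a measured number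

For the measured compounds named here, compound 2 holds the only number in this small set, since the result for compound 1 is a limit. Compound 3 `COC(=O)N[C@H](C(=O)N1C[C@@H](C)C[C@H]1c1ncc(-c2ccc(-c3ccc(-c4cc5[nH]c([C@@H]6C[C@H](C)CN6C(=O)[C@@H](NC(=O)OC)C(C)C)nc5s4)cc3C)cc2)[nH]1)C(C)C` differs from compound 2 by methyl in place of fluoro on an aromatic carbon, ortho to a large group and meta to a large group (methyl in place of fluoro on an aromatic carbon). Going by the values given here, no measured pair shows this change or any other single change, so the expectation rests on compound 2 at 20000 nM alone. No step beyond the usual scatter is expected in this assay for this exchange. The expected step of no change at the digits printed from compound 2 to compound 3 (within the scatter) stays within that scatter. Compound 3 is estimated at 20000 nM (expected range 9000 nM to 40000 nM).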

Compound 3, half-maximal cytotoxic concentration: 19200 nM
Compound 3: middle estimate off by 1.0-fold (0.02 log units), on the high side; the measured number falls inside the stated range.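

In this assay, for the compounds shown here, methyl in place of fluoro on this aromatic carbon, ortho to a large group and meta to a large group, gives a 1.0-fold lower number from compound 2 to compound 3 (0.02 log units; within the scatter), the first single change that can be read. At this position, the two groups are therefore not told apart in this test. Compound 1 is reported only as a limit, and the reading for this change lies up against that limit, so the test has little room to show a step upward: the limit of > 20000 nM in this assay, at which 1 of the 3 values shown sits.

The compounds shown leave open whether an amine, a carboxylic acid or a longer chain on this carbon would bring the number down from this level. They also leave open whether methyl in place of fluoro would read the same elsewhere on the core, or in compounds with values far from that limit.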